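The source may report more compounds than this note shows. Statements on the series, on what has been measured and on what is new or still open speak of the compounds shown alone.

Measured so far in an ADME assay on isolated protein for pharmacokinetics, with UDP-glucuronosyltransferase 1A9 (Homo sapiens) as the target, read by LC-MS, with a stated time of 60 min, at 37 degrees C, tested at 1 uM, in the presence of a further agent that is not named here; on this read-out higher numbers stand for a longer-lived compound and lower numbers for a shorter-lived compound:
Compound 1, `NS(=O)(=O)CC(=O)NCCSc1nonc1/C(=N/O)Nc1cccc(C(F)F)c1`, gives > 3 h, which is a limit of the assay rather than a number.
Compound 2, `NS(=O)(=O)CC(=O)NCCSc1nonc1/C(=N/O)Nc1cccc(Br)c1`, gives 0.955 h.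
Compound 3, `N#Cc1cccc(N/C(=N\O)c2nonc2SCCNC(=O)CS(N)(=O)=O)c1`, gives > 3 h, again a limit of the assay.

Compound 1 thus stands at the limit of > 3 h in this assay, at which 2 of the 3 values shown sit, so its true half-life is not pinned down. Compound 4, `NS(=O)(=O)CC(=O)NCCSc1nonc1/C(=N/O)Nc1ccc(F)c(C(F)F)c1`, differs from compound 1 by fluoro in place of hydrogen on an aromatic carbon. Among the compounds with values here, no measured step adds a fluoro; the measured steps only swap the group already present: an at least 3.1-fold lower number from compound 1 to compound 2 (0.49 log units; beyond the scatter), while a step that the two limits leave unreadable from compound 1 to compound 3 and an at least 3.1-fold higher number from compound 2 to compound 3 (0.49 log units; beyond the scatter). Compound 1 already sits at the long-lived end, and none of these steps speaks to an added fluoro. The expected outcome is no step beyond the scatter, a step that the limit leaves unreadable from compound 1 to compound 4. Compound 4 is estimated at 4 h, between 1.5 h and 10 h.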

Compound 4, half-life: > 3 h
Compound 4: a limit, no number; the forecaster's own chance of this, stated with the estimate: 65%; the middle value is on the limit's open side.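

In this assay compound 4 gives > 3 h, which is a limit of the assay and not a number. Fluoro on the aromatic carbon ortho to the difluoromethyl group therefore leaves the half-life at that limit, and the new ring still shows an at least 3.1-fold higher number from compound 2 to compound 4 (0.49 log units; beyond the scatter). The steps to compound 4 from compound 1 and compound 3 cannot be read, and the values now crowd at one end: the limit of > 3 h in this assay, at which 3 of the 4 values shown sit.

Going by these compounds, whether fluoro changes the true half-life at all stays open. So does the effect of an amine or a carboxylic acid on that same carbon.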